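The source may report more compounds than this note shows. Statements on the series, on what has been measured and on what is new or still open speak of the compounds shown alone.

Three members of the series share one core and differ only in the group on a nitrogen on an aromatic ring: compound 1 `CCCCNc1cc(Oc2c(OC)cc3cc(C#N)ccc3c2OC)nc(Nc2ccc(C#N)cc2)n1`, compound 2 `COc1cc2cc(C#N)ccc2c(OC)c1Oc1cc(NCC(C)C)nc(Nc2ccc(C#N)cc2)n1` and compound 3 `CCCCCC(C)Nc1cc(Oc2c(OC)cc3cc(C#N)ccc3c2OC)nc(Nc2ccc(C#N)cc2)n1`. In an ADME assay on MT4 cells (Homo sapiens) for cytotoxicity, read by MTT assay, with a stated time of 5 days (a lower number here means that less compound is tolerated, a higher number that more compound is tolerated), compound 1 gives only a limit, > 125000 nM. Compound 2 likewise reaches only a limit in this assay, > 125000 nM. Compound 3 also stops at a limit in this assay, > 125000 nM. All three sit at the limit of > 125000 nM in this assay, at which 3 of the 3 values shown sit, so a step that the two limits leave unreadable from compound 1 to compound 2, a step that the two limits leave unreadable from compound 1 to compound 3 and a step that the two limits leave unreadable from compound 2 to compound 3 cannot be sized. Compound 4 `COc1cc2cc(C#N)ccc2c(OC)c1Oc1cc(NC2CC2)nc(Nc2ccc(C#N)cc2)n1` differs from compound 2 in one place: cyclopropyl in place of isobutyl on a nitrogen on an aromatic ring. Among the measured compounds shown here, no measured step on this kind of change is readable, and none of the three limits points to a detectable step in this assay. The expected step that the limit leaves unreadable from compound 2 to compound 4 is therefore none beyond the scatter. Compound 4 is estimated at 150000 nM, within 90000 nM to 300000 nM, most likely again only a limit.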

Compound 4, half-maximal cytotoxic concentration: > 125000 nM
Compound 4 was reported as a limit; the forecaster's own chance of this, stated with the estimate: 85%; the middle value lies beyond the limit too.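

Among the compounds shown here, no step between compound 4 and compound 1, compound 2 or compound 3 can be read in this assay because all four stop at a limit: the limit of > 125000 nM in this assay, at which 4 of the 4 values shown sit.

On these data alone, whether these four groups on the nitrogen differ at all in this assay stays open.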